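Exchanging the aryl group on a shared thiosemicarbazone core

The source may hold more compounds than are shown below. What is called first, only, known or untested is meant among the compounds shown, and "the series" means these compounds.

Of the compounds shown here, three built on one shared core have been tested in a functional assay on COS-7 cells (Chlorocebus aethiops) for inhibition, read by MTT assay; a higher number here means a weaker inhibitor, a lower number a stronger inhibitor. Compound 1 `O=C1Nc2ccc(Br)cc2/C1=N/NC(=S)N/N=C/c1ccc(Br)cc1` gives 5180 nM. Compound 2 `O=C1Nc2ccc(Br)cc2/C1=N/NC(=S)N/N=C/c1c(Cl)cccc1Cl` gives 6730 nM, and compound 3 `COc1ccc(/C=N/NC(=S)N/N=C2\C(=O)Nc3ccc(Br)cc32)cc1O` gives 3090 nM. Compound 3 thus holds the lowest of the three numbers, though the gap a 1.7-fold lower number from compound 1 to compound 3 (0.22 log units; within the scatter) is within the scatter, while the gap a 2.2-fold lower number from compound 2 to compound 3 (0.34 log units; beyond the scatter) is beyond it. The remaining step, a 1.3-fold higher number from compound 1 to compound 2 (0.11 log units; within the scatter), is also within the scatter.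

Compound 4 `Cc1ccc(O)c(/C=N/NC(=S)N/N=C2\C(=O)Nc3ccc(Br)cc32)c1` differs from compound 3 in a single place: 2-hydroxy-5-methylphenyl in place of 3-hydroxy-4-methoxyphenyl on a carbon with a double bond to nitrogen. All three measured steps exchange the aryl group on this same carbon, and none moves the number by much. Compound 4 is therefore expected to stay close to compound 3 in this assay, with the step of a 1.4-fold higher number from compound 3 to compound 4 (0.13 log units; within the scatter) expected to be small and, if anything, toward a higher number. Compound 4 is estimated at 4200 nM, with a range from 1800 nM to 9500 nM.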

Compound 4, half-maximal inhibitory concentration: > 50000 nM
Compound 4 was reported as a limit; the forecaster's own chance of this, stated with the estimate: 5%; middle value at least 11-fold (1.07 log units) away from the limit.
By their numbers in this assay, from the lowest: compounds 3, 1 and 2 (each within the scatter of the next, the first and the last beyond it). At a limit, above all of these: compound 4.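

Compound 4 stands at a limit of this assay, not at a number: the limit of > 50000 nM in this assay, at which 1 of the 4 values shown sits.

The carbon with a double bond to nitrogen, where the three earlier aryl groups stayed close together, can therefore carry a large change: an at least 16-fold higher number from compound 3 to compound 4 (1.20 log units; beyond the scatter), alongside an at least 7.4-fold higher number from compound 2 to compound 4 (0.87 log units; beyond the scatter) and an at least 9.6-fold higher number from compound 1 to compound 4 (0.98 log units; beyond the scatter). Compound 3 and compound 4 both carry a hydroxy group on the aryl ring, so the presence of that group alone does not hold the number low.

Which feature of 2-hydroxy-5-methylphenyl carries this step stays open, as the methyl group, the loss of the methoxy group and the different hydroxy-bearing ring all enter in one exchange. Also open, going by these compounds, is how an aryl ring bearing an amine or a carboxylic acid would behave on this carbon.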